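The source may hold more compounds than are shown below. What is called first, only, known or untested is meant among the compounds shown, and "the series" means these compounds.

Of the compounds shown here, three sharing one core have been measured. Compound 1 `OC1(COc2ccc([C@H]3CC[C@]4(CC3)OOC3(O4)C4CC5CC(C4)CC3C5)cc2)CCNCC1` carries a 4-hydroxypiperidin-4-yl group on a saturated chain carbon bound to an oxygen on an aromatic ring, and in an ADME assay on microsomes from liver (Homo sapiens) for metabolic stability, read by LC-MS, tested at 1 uM (on this read-out higher numbers stand for fast clearance and lower numbers for slow clearance), compound 1 gives 16 mL.min-1.g-1. Compound 2 `CS(=O)(=O)N1CCN(CCCOc2ccc([C@H]3CC[C@]4(CC3)OOC3(O4)C4CC5CC(C4)CC3C5)cc2)CC1` gives 68 mL.min-1.g-1 in this assay, a step of a 4.3-fold higher number from compound 1 to compound 2 (0.63 log units; beyond the scatter). Compound 3 `O[C@H]1CC[C@H](NCCCOc2ccc([C@H]3CC[C@]4(CC3)OOC3(O4)C4CC5CC(C4)CC3C5)cc2)CC1` reports only a limit in this assay: compound 3 gives < 7 mL.min-1.g-1, which is the limit of < 7 mL.min-1.g-1 in this assay, at which 1 of the 3 values shown sits. The steps into it read an at least 2.2-fold lower number from compound 1 to compound 3 (0.35 log units; beyond the scatter) and an at least 9.7-fold lower number from compound 2 to compound 3 (0.98 log units; beyond the scatter), so compound 3 stands at the slow end of what is known.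

Compound 4 `c1cc([C@H]2CC[C@]3(CC2)OOC2(O3)C3CC4CC(C3)CC2C4)ccc1OCCOC1CCNCC1` has not yet been measured. It differs from compound 3 by (piperidin-4-yl)oxy in place of ((4-hydroxycyclohexyl)amino)methyl on a saturated chain carbon, two bonds along the chain from an oxygen on an aromatic ring. Of the measured steps, the nearest comparison is an at least 2.2-fold lower number from compound 1 to compound 3 (0.35 log units; beyond the scatter), since the change in compound 4 resembles a partial return toward the 4-hydroxypiperidin-4-yl pattern of compound 1. Compound 4 is therefore expected to give 11 mL.min-1.g-1, between 5 mL.min-1.g-1 and 25 mL.min-1.g-1, with the estimated step being an at least 1.5-fold higher number from compound 3 to compound 4 (0.19 log units; that floor lies within the scatter).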

Compound 4, intrinsic clearance in microsomes: < 7 mL.min-1.g-1
Compound 4: only a limit was reported; the forecaster's own chance of this, stated with the estimate: 30%; middle value at least 1.5-fold (0.19 log units) from the limit.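

In this assay compound 4 reports only a limit, < 7 mL.min-1.g-1. Compound 3 reports the same limit, so the step between these two cannot be read: the limit of < 7 mL.min-1.g-1 in this assay, at which 2 of the 4 values shown sit.

What compound 4 adds is a second group that stays at the slow end, with an at least 9.7-fold lower number from compound 2 to compound 4 (0.98 log units; beyond the scatter) and an at least 2.2-fold lower number from compound 1 to compound 4 (0.35 log units; beyond the scatter). Among the four compounds, a slow read-out at this position therefore does not depend on the (4-hydroxycyclohexyl)amino group, although compound 2 shows that not every amine-bearing group there gives one.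

Going by these compounds, how far compound 3 and compound 4 lie past the limit stays open, and so does their order. Also open, on these data alone, is whether an acetyl group on the nitrogen of the piperidin-4-yl ring, or a longer chain carrying the (piperidin-4-yl)oxy group, would stay at that limit.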